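Sulfonyl aryl swap in a quinoline sulfone series

The compounds below may be only part of what the source reports. "The series", "measured", "known", "first", "only" and "open" are said of these compounds alone.

Measured compounds:
compound 1 `Cc1ccc2ncc(S(=O)(=O)c3cc(Cl)cc(Cl)c3)c(N3CCC(C)CC3)c2c1`: 75%
compound 2 `Cc1ccc2ncc(S(=O)(=O)c3ccc(C)c(Cl)c3)c(N3CCC(C)CC3)c2c1`: 91%
compound 3 `CC1CCN(c2c(S(=O)(=O)c3cc(Cl)cc(Cl)c3)cnc3cc(Cl)ccc23)CC1`: 93%

In an assay on isolated protein for displacement of a labelled ligand from metabotropic glutamate receptor 5 (Homo sapiens), with a stated time of 60 min, tested at 1 uM (a lower number here means less inhibition, a higher number more inhibition at the concentration tested (going by the name of the read-out)), compound 1 gives 75% and compound 2 gives 91%. The change between them is 3-chloro-4-methylphenyl in place of 3,5-dichlorophenyl on a sulfonyl sulfur and it made a step of a number 16 percentage points higher from compound 1 to compound 2 (beyond the scatter). Compound 3 gives 93% in this assay, the highest of the three values; its difference from compound 2 is within the scatter, its difference from compound 1 is beyond it. How the core of compound 3 differs from the core of compound 1 is not broken down here.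

Compound 4 `Cc1ccc(S(=O)(=O)c2cnc3cc(Cl)ccc3c2N2CCC(C)CC2)cc1Cl` is not yet measured. It differs from compound 3 by 3-chloro-4-methylphenyl in place of 3,5-dichlorophenyl on a sulfonyl sulfur, the same change, at the same place, as that from compound 1 to compound 2. Because that step was a number 16 percentage points higher from compound 1 to compound 2 (beyond the scatter), a rise is expected for compound 4 as well, but it is expected to be smaller, a number 2 percentage points higher from compound 3 to compound 4 (within the scatter), since compound 3 already gives 93% and the read-out cannot rise much further. Compound 4 is therefore estimated at 95%, between 88% and 99%.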

Compound 4, a percentage reported as inhibition, at one concentration (the size of the read-out at that concentration, not a potency): 89%
The estimate for compound 4 lay 6 percentage points above the measured number; low and high end bracket the measured number.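

In this assay, 3-chloro-4-methylphenyl in place of 3,5-dichlorophenyl on a sulfonyl sulfur gave a number 4 percentage points lower from compound 3 to compound 4 (within the scatter). The gain seen on the core of compound 1 therefore did not carry over to the core of compound 3, and the two steps differ: the same change on two cores in this assay, a number 16 percentage points higher (beyond the scatter) from compound 1 to compound 2 and a number 4 percentage points lower (within the scatter) from compound 3 to compound 4, 20 percentage points apart, beyond the scatter of two such steps
Among these compounds, this does not show why the steps differ or whether the swap has any real effect on the core of compound 3, since compound 3 gives 93% and compound 4 gives 89%, percentages at one concentration that are not potencies, and only two pairs of compounds are available.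

Still open, on these data alone, is whether full concentration-response measurements would separate compound 3 from compound 4, and how the same swap behaves on further cores. Also open, as far as these compounds go, is how a sulfonyl aryl group carrying a carboxylic acid or a morpholine would read in this assay.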